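Swapping the benzamide aryl group in a cytotoxic thiazole series

The compounds below may be only part of what the source reports. "The series", "measured", "known", "first", "only" and "open" are said of these compounds alone.

The measured compounds and their values in a functional assay on SK-MEL-28 cells (Homo sapiens) for cytotoxicity, read by MTT assay; on this read-out lower numbers stand for stronger inhibition and higher numbers for weaker inhibition:
- compound 1 `O=C(NCCNc1nccc(-c2c(-c3cccc(F)c3)nc3sccn23)n1)c1ccc(C(F)(F)F)cc1` gives 9260 nM
- compound 2 `O=C(NCCNc1nccc(-c2c(-c3cccc(F)c3)nc3sccn23)n1)c1ccc(Cl)cc1` gives 8160 nM
- compound 3 `O=C(NCCCNc1nccc(-c2c(-c3cccc(F)c3)nc3sccn23)n1)c1ccc(Cl)cc1` reaches only the limit > 20000 nM

Compound 1 and compound 2 share the same core and differ only in the group on the benzamide ring; the step of a 1.1-fold lower number from compound 1 to compound 2 (0.05 log units; within the scatter) stays within the scatter, so the two sit at essentially the same level. Compound 1 has the highest of the two numbers, with compound 2 nearest. Compound 3 lengthens the chain, and the step of an at least 2.4-fold higher number from compound 2 to compound 3 (0.38 log units; beyond the scatter) is at least modest; its value is a limit of this assay the limit of > 20000 nM in this assay, at which 1 of the 3 values shown sits, rather than a number.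

Compound 4 `O=C(NCCNc1nccc(-c2c(-c3cccc(F)c3)nc3sccn23)n1)c1c(F)cccc1F` is not yet measured. It differs from compound 1 in one place: 2,6-difluorophenyl in place of 4-(trifluoromethyl)phenyl on a carbonyl carbon. For the measured compounds named here, the only measured step that bears on such a swap on the benzamide ring is the step from compound 1 to compound 2, which lay within the scatter; the chain step from compound 2 to compound 3 does not touch this part. Compound 4 is therefore expected to stay near compound 1, with a step of a 1.1-fold higher number from compound 1 to compound 4 (0.03 log units; within the scatter) that should not go beyond the scatter. Compound 4 is estimated at 10000 nM, within 4000 nM to 25000 nM.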

Compound 4, half-maximal inhibitory concentration: 11400 nM
The estimate for compound 4 lay 1.1-fold (0.06 log units) below the measured number, and the stated range covers the measured number.
By their numbers in this assay, from the lowest: compounds 2, 1 and 4 (each within the scatter of the next). At a limit, above all of these: compound 3.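

In this assay, the benzamide position now tolerates a change in the pattern of ring substitution as well as a change of a single group: the step with 2,6-difluorophenyl in place of 4-(trifluoromethyl)phenyl is a 1.2-fold higher number from compound 1 to compound 4 (0.09 log units; within the scatter), and the step with the same group in place of 4-chlorophenyl is a 1.4-fold higher number from compound 2 to compound 4 (0.15 log units; within the scatter), so compounds 1, 2 and 4 all remain at one level. The remaining step, an at least 1.7-fold lower number from compound 3 to compound 4 (0.24 log units; that floor lies within the scatter), starts from a limit and spans a change in both the chain and the aryl group, so it cannot be read. The data shown give no cause for this flat response at the aryl position.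

Going by these compounds, whether an amine, a carboxylic acid or a pyridine ring in place of these halogenated phenyl groups would move the number beyond the scatter remains open. On these data alone, it is also open whether 2,6-difluorophenyl on the longer chain of compound 3, or an aliphatic group such as cyclohexyl on the carbonyl carbon, would change the picture.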